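Chain and ester swaps on the shared core: cytotoxicity notes

The source may report more compounds than this note shows. Statements on the series, on what has been measured and on what is new or still open speak of the compounds shown alone.

Three compounds on one shared core have been run in an ADME assay on HEK293 cells (Homo sapiens) for cytotoxicity, read by sulforhodamine B assay, with a stated time of 48 h, tested at 10 uM; on this read-out higher numbers stand for more inhibition at the one concentration tested (going by the name of the read-out) and lower numbers for less inhibition. Compound 1 `CCCCCCc1cn(C(c2ccccc2)c2cc3cc(Br)ccc3nc2OC)nn1` gives -3.17%. Compound 2 `COc1nc2ccc(Br)cc2cc1C(c1ccccc1)n1cc(-c2ccccc2F)nn1` gives 3.97%. Compound 3 `CCOC(=O)c1cn(C(c2ccccc2)c2cc3cc(Br)ccc3nc2OC)nn1` gives 2%, the second highest of the three numbers, with compound 2 nearest and compound 1 furthest; all three sit within the scatter of one another, as a number 7.1 percentage points higher from compound 1 to compound 2 (within the scatter), a number 5.2 percentage points higher from compound 1 to compound 3 (within the scatter) and a number 2 percentage points lower from compound 2 to compound 3 (within the scatter) show. Compound 4 `COc1nc2ccc(Br)cc2cc1C(c1ccccc1)n1cc(CCCCCO)nn1` differs from compound 3 by 5-hydroxypentyl in place of ethoxycarbonyl on an aromatic carbon. Among the compounds with values here, the only measured step that exchanges a chain for the ethoxycarbonyl group, a number 5.2 percentage points higher from compound 1 to compound 3 (within the scatter), was within the scatter, and no step in this assay has yet exceeded it, so the expected step is a number 1 percentage points lower from compound 3 to compound 4 (within the scatter), nothing beyond the scatter. Compound 4 is therefore estimated at 1%, in the range -9% to 11%.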

Compound 4, a percentage reported as inhibition, at one concentration (the size of the read-out at that concentration, not a potency): 7.96%
For compound 4 the middle estimate is 7 percentage points below the measured one, within the range that was stated.
By their numbers in this assay, from the lowest: compounds 1, 3, 2 and 4 (each within the scatter of the next, the first and the last beyond it).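

Hydroxy in place of methyl on a saturated chain carbon, five bonds along the chain from an aromatic carbon, gives a number 11.1 percentage points higher from compound 1 to compound 4 (beyond the scatter) in this assay and is the only step in the series beyond the scatter. By contrast, a number 6 percentage points higher from compound 3 to compound 4 (within the scatter) and a number 4 percentage points higher from compound 2 to compound 4 (within the scatter) leave 5-hydroxypentyl not separable from ethoxycarbonyl or 2-fluorophenyl at this position. Nothing available explains the hydroxy step.
As far as these compounds go, whether an amine or a carboxylic acid at the chain end, or a longer chain bearing the hydroxy, would shift the number further remains open.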